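Acetoxy to (Propylcarbonyl)oxy on Compound 1

The compounds below may be only part of what the source reports. "The series", "measured", "known", "first", "only" and "open" are said of these compounds alone.

Compound 1 `CC(=O)OCc1ccc2oc(=O)c(C(=O)Oc3cccc(Br)c3)cc2c1` gives 11.8% in a functional assay on HT-1080 cells (Homo sapiens), read by transwell migration, with a stated time of 24 h, tested at 10 uM (on this read-out higher numbers stand for a weaker effect at the one concentration tested and lower numbers for a stronger effect), the lowest of the three numbers measured. Compound 2 `CC(=O)OCc1ccc2oc(=O)c(C(=O)Sc3cccc(Cl)c3)cc2c1` gives 61.9% and compound 3 `CC(=O)OCc1ccc2oc(=O)c(C(=O)Nc3cccc(Cl)c3)cc2c1` gives 42.8%; the steps of a number 50.1 percentage points higher from compound 1 to compound 2 (beyond the scatter) and a number 31 percentage points higher from compound 1 to compound 3 (beyond the scatter) are both large, while a number 19.1 percentage points lower from compound 2 to compound 3 (beyond the scatter) is modest. Compound 4 `CCCC(=O)OCc1ccc2oc(=O)c(C(=O)Oc3cccc(Br)c3)cc2c1` differs from compound 1 by ethyl in place of hydrogen on a saturated chain carbon bound to a carbonyl carbon. Going by the values given here, none of the measured steps bears on this change: all three replace the 3-bromophenoxy group on a carbonyl carbon and leave the acetoxy chain untouched. There is therefore no basis for expecting a step beyond the scatter, and the estimate for compound 4 is 15%, between 4% and 35%. The expected step is a number 3.2 percentage points higher from compound 1 to compound 4 (within the scatter).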

Compound 4, a percentage reported as activity, at one concentration (the size of the read-out at that concentration, not a potency): 24.7%
Estimate against measurement, compound 4: 9.7 percentage points below; the measured number falls inside the stated range.
By their numbers in this assay, from the lowest: compound 1; then compound 4; then compound 3; then compound 2.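

Going from acetoxy to (propylcarbonyl)oxy is not a silent change in this assay: the step is a number 12.9 percentage points higher from compound 1 to compound 4 (beyond the scatter), so the saturated chain, untouched by the earlier compounds, also affects the read-out, here toward a weaker effect. The step is modest, whereas the replacements of 3-bromophenoxy were large. No measurement shown accounts for this step. Going by these compounds, whether a longer chain, a branched chain or a chain carrying an amine would move the number further remains open. So does whether the step would recur with (3-chlorophenyl)amino on the carbonyl carbon.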